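This account rests on a few compounds, and the source may have more. Where it says the series, first, only, none or still open, it means among the compounds named here.

Of the compounds shown here, three with a shared core have been measured in an assay on CHO cells for displacement of a labelled ligand from adenosine receptor A1 (Homo sapiens), read by scintillation counting, with a stated time of 1 h, tested at 1 uM; a lower number here means less inhibition, a higher number more inhibition at the concentration tested (going by the name of the read-out). Compound 1 `Nc1ncc(-c2cccc(F)c2)c(-c2ccccc2)n1` gives 63%. Compound 2 `Nc1ncc(-c2cccc(Cl)c2)c(-c2ccccc2)n1` reaches a limit of the assay, > 80%, so only a boundary rather than a number is known for it. Compound 3 `Nc1ncc(-c2ccc(O)c(Cl)c2)c(-c2ccccc2)n1` likewise sits at a limit, > 80%. The step of a number at least 17 percentage points higher from compound 1 to compound 2 (beyond the scatter) comes from chloro in place of fluoro on an aromatic carbon, while the step that the two limits leave unreadable from compound 2 to compound 3 cannot be sized because of the limit of > 80% in this assay, at which 2 of the 3 values shown sit.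

Compound 4 `Clc1cccc(-c2cnc(NC3CCCCC3)nc2-c2ccccc2)c1` is not yet measured. It differs from compound 2 by cyclohexyl in place of hydrogen on a nitrogen on an aromatic ring. For the measured compounds named here, neither measured step touches that nitrogen; both change the aromatic ring, so no step gives a direction for this change. Compound 2 already stands at the limit, so a move upward cannot show. The expectation for compound 4 is therefore wide, with 70% between 40% and 95%, meaning an estimated step of a number at least 10 percentage points lower from compound 2 to compound 4 (that floor lies within the scatter).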

Compound 4, a percentage reported as inhibition, at one concentration (the size of the read-out at that concentration, not a potency): 58%
The estimate for compound 4 lay 12 percentage points above the measured number; the measured number falls inside the stated range.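

In this assay, for the compounds shown here, cyclohexyl in place of hydrogen on a nitrogen on an aromatic ring gives a number at least 22 percentage points lower from compound 2 to compound 4 (beyond the scatter), so this nitrogen, which the earlier steps left untouched, is a place where a change shows in the read-out. The inhibition is reduced but not lost, as compound 4 still gives 58%. The full size of the step cannot be stated, because compound 2 sits at a limit and not at a number: the limit of > 80% in this assay, at which 2 of the 4 values shown sit.

Cyclohexyl is the only group shown on this nitrogen, so it stays open whether a small methyl group, an open chain such as hexyl, or a flat phenyl ring would give a similar number. As far as these compounds go, it is also open whether the same change would give a similar step with the fluoro group of compound 1 in place of the chloro group.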